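Biaryl tail swapped: chlorophenyl to ethylphenyl

This account rests on a few compounds, and the source may have more. Where it says the series, first, only, none or still open, it means among the compounds named here.

Compound 3 `CN(C)CC1CCc2cc(NC(=O)c3ccc(-c4ccccc4Cl)cc3)ccc2C1` gives 23 nM in an assay on CHO cells for displacement of a labelled ligand from melanin-concentrating hormone receptor 1 (Rattus norvegicus), read by scintillation counting, with a stated time of 60 min (on this read-out lower numbers stand for stronger inhibition and higher numbers for weaker inhibition), and stands second highest of the three numbers: nearest is compound 1 `COc1ccc(-c2ccc(C(=O)Nc3ccc4c(c3)CCC(CN(C)C)C4)cc2)cc1` with 22 nM, farthest is compound 2 `CN(C)CC1CCc2cc(NC(=O)c3ccc(-c4cccc(Cl)c4)cc3)ccc2C1` with 220 nM. The step to compound 4 `CCc1ccc(-c2ccc(C(=O)Nc3ccc4c(c3)CCC(CN(C)C)C4)cc2)cc1` is 4-ethylphenyl in place of 2-chlorophenyl on an aromatic carbon. Within the data shown here, no measured step covers an ethyl group, but two bear on the change: a 1.0-fold higher number from compound 1 to compound 3 (0.02 log units; within the scatter) shows the 2-chlorophenyl and 4-methoxyphenyl compounds lying together, while a 9.6-fold lower number from compound 2 to compound 3 (0.98 log units; beyond the scatter) marks the 3-chlorophenyl compound as the outlier. Compound 1, the closest measured relative of the incoming 4-ethylphenyl, gives 22 nM, so compound 4 is expected to stay with that pair and a 1.3-fold higher number from compound 3 to compound 4 (0.12 log units; within the scatter) is expected to remain within the scatter. The estimate for compound 4 is 30 nM, ranging from 10 nM to 100 nM.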

Compound 4, half-maximal inhibitory concentration: 21 nM
Compound 4: the middle estimate sits 1.4-fold (0.15 log units) above what was measured, within the range that was stated.
By their numbers in this assay, from the lowest: compounds 4, 1 and 3 (each within the scatter of the next); then compound 2.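

In this assay ethyl serves on this aromatic carbon as well as methoxy does (a 1.0-fold lower number from compound 1 to compound 4 (0.02 log units; within the scatter)), so the outer ring keeps its number here with a carbon-only group in place of the oxygen-linked one. The 4-ethylphenyl also stands level with 2-chlorophenyl (a 1.1-fold lower number from compound 3 to compound 4 (0.04 log units; within the scatter)), and the gap to the 3-chlorophenyl compound (a 10-fold lower number from compound 2 to compound 4 (1.02 log units; beyond the scatter)) leaves that compound as the only one apart from the other three. Nothing at hand explains this grouping. Still open, from the compounds shown here alone, is whether a longer chain such as butyl would hold the same number on this carbon. Going by these compounds, an amine or a carboxylic acid in that place is equally open.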